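The source may hold more compounds than are shown below. What is called first, only, known or untested is meant among the compounds shown, and "the series" means these compounds.

The measured compounds:
Compound 1 `Cc1nnc(N2CCC(C(=O)N3N=CC[C@H]3c3cc(F)cc(F)c3)CC2)o1` gives 1.7 h in an ADME assay on the whole organism (Rattus norvegicus) for metabolic stability, at a dose of 1 mg/kg by the intravenous route; on this read-out higher numbers stand for a longer-lived compound and lower numbers for a shorter-lived compound.
Compound 2 `O=C(c1cn[nH]c1)N1CCC(C(=O)N2N=CCC2c2ccccc2)CC1` gives 0.417 h in this assay.
Compound 3 `O=C(c1cnco1)N1CCC(C(=O)N2N=CC[C@H]2c2ccccc2)CC1` gives 0.467 h in this assay.

Compound 1 stands highest of the three numbers, with compound 3 the nearest and compound 2 the furthest; both gaps lie beyond the scatter, so compound 1 is the longest-lived of the three. Compound 4 `N#Cc1cc(N2CCC(C(=O)N3N=CC[C@H]3c3cc(F)cc(F)c3)CC2)ncn1` has not yet been measured. It differs from compound 1 in one place: a group of 8 heavy atoms (5 carbon, 3 nitrogen; one six-membered aromatic ring with 2 hetero atoms) in place of a group of 6 heavy atoms (3 carbon, 2 nitrogen, 1 oxygen; one five-membered aromatic ring with 3 hetero atoms), on an amine nitrogen in a ring. Among the compounds with values here, no pair of measured compounds differs in one place, so no step of this kind is known. The expectation for compound 4 is a step of a 1.1-fold lower number from compound 1 to compound 4 (0.05 log units; within the scatter) that stays within the scatter, in either direction. Compound 4 is therefore expected to give 1.5 h, within a range from 0.6 h to 3.5 h.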

Compound 4, half-life: 1.65 h
The estimate for compound 4 lay 1.1-fold (0.04 log units) below the measured number, within the range that was stated.
By their numbers in this assay, from the lowest: compounds 2 and 3 (each within the scatter of the next); then compounds 4 and 1 (each within the scatter of the next).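

In this assay the 5-methyl-1,3,4-oxadiazol-2-yl group on the amine nitrogen in the ring gives way to a six-membered aromatic ring with 2 hetero atoms and a nitrile, with a 1.0-fold lower number from compound 1 to compound 4 (0.01 log units; within the scatter). Within the data shown here, this is the first one-place step in the set, and it shows that this position accepts a larger six-membered ring in place of the five-membered one with no half-life difference that can be told from the scatter. Nothing available explains why the two groups read alike. As far as these compounds go, whether a non-aromatic group at this nitrogen, such as an acetyl group or a simple ethyl chain, would read alike remains open.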